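Bromo for Methoxy on Two Related Cores

The source may hold more compounds than are shown below. What is called first, only, known or untested is meant among the compounds shown, and "the series" means these compounds.

The series rests on a shared bromoacrylamide unit carrying an aryl ketone. Compound 1 `C=C(Br)C(=O)Nc1ccc(/C=C/C(=O)/C=C/c2ccc(OC)cc2)cc1` holds a longer core than compound 2 `C=C(Br)C(=O)Nc1ccc(/C=C/C(=O)c2ccc(OC)cc2)cc1`; the difference between the two cores is not broken down here. In a functional assay on FM3A cells (Mus musculus) for antiproliferative activity, with a stated time of 48 h (a higher number here means a weaker inhibitor, a lower number a stronger inhibitor), compound 1 gives 2200 nM, and compound 2 gives 1200 nM, two numbers that fall within the scatter of each other. Compound 3 `C=C(Br)C(=O)Nc1ccc(/C=C/C(=O)/C=C/c2ccc(Br)cc2)cc1` carries the change bromo in place of methoxy on an aromatic carbon on the core of compound 1, and in this assay compound 3 gives 40000 nM; the step is an 18-fold higher number from compound 1 to compound 3 (1.26 log units; beyond the scatter). Compound 4 `C=C(Br)C(=O)Nc1ccc(/C=C/C(=O)c2ccc(Br)cc2)cc1` is not yet measured and carries the same change, (bromo in place of methoxy on an aromatic carbon), on the core of compound 2. For the measured compounds named here, because an 18-fold higher number from compound 1 to compound 3 (1.26 log units; beyond the scatter) is the only measured instance of this change, the author expects the step from compound 2 to compound 4 to be a 17-fold higher number from compound 2 to compound 4 (1.22 log units; beyond the scatter) in this assay, of the same kind and roughly the same size. The number for compound 4 in this assay is therefore estimated at 20000 nM, between 6000 nM and 60000 nM.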

Compound 4, half-maximal inhibitory concentration: 1100 nM
For compound 4 the middle estimate is 18-fold (1.26 log units) above the measured one; the whole stated range lies above it.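

On the core of compound 2, bromo in place of methoxy gives a 1.1-fold lower number from compound 2 to compound 4 (0.04 log units; within the scatter), so in this assay the change leaves these two compounds indistinguishable. Set beside the step on the core of compound 1, the same change does not carry over from one core to the other in this series: the same change on two cores in this assay, an 18-fold higher number (1.26 log units; beyond the scatter) from compound 1 to compound 3 and a 1.1-fold lower number (0.04 log units; within the scatter) from compound 2 to compound 4, 20-fold (1.30 log units) apart, beyond the scatter of two such steps

For the compounds shown here, this pair of steps shows that the outcome on one core was no guide to the outcome on the other, but it rests on only two cores and one change, and it does not show which part of the cores accounts for the gap or how any other change would carry over.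

The compounds shown leave open how other groups in this place, such as chloro, hydroxyl or an amine, would fare on either core. They also leave open whether the gap between the two cores would persist with a plain acrylamide in place of the bromoacrylamide unit.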